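Series notes: fluoro for methoxy on the distal aryl ring

The source may hold more compounds than are shown below. What is called first, only, known or untested is meant among the compounds shown, and "the series" means these compounds.

Measured so far:
- compound 1, `CCOC(=O)CCCCCOc1cccc(CN(C(=O)c2ccc(-c3ccncc3)cc2)C(C)C)c1`: in an ADME assay on BJ cells (Homo sapiens) for cytotoxicity, read by CellTiter-Glo and resazurin assay, with a stated time of 72 h (on this read-out lower numbers stand for an effect already at smaller amounts and higher numbers for an effect only at larger amounts of compound), compound 1 gives > 26000 nM, a limit of the assay.
- compound 2, `CCOC(=O)CCCCCOc1cccc(CN(C(=O)c2ccc(-c3cc(OC)cc(OC)c3)cc2)C(C)C)c1`: in this assay compound 2 gives > 26000 nM, also a limit of the assay.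

Going by the values given here, compound 2 stands only as a limit; no number is known for it, and the one other value shown is a limit as well. The step that the two limits leave unreadable from compound 1 to compound 2 therefore cannot be read from the two limits. Among the compounds with values here, both values sit at the limit of > 26000 nM in this assay, at which 2 of the 2 values shown sit, so no measured step gives a size or a direction.

Compound 3, `CCOC(=O)CCCCCOc1cccc(CN(C(=O)c2ccc(-c3cc(F)cc(OC)c3)cc2)C(C)C)c1`, is to be measured in this assay. It differs from compound 2 as follows: fluoro in place of methoxy on an aromatic carbon. Within the data shown here, neither measured step bears on this change in a readable way, since the only step available is unreadable. With both neighbours at the assay limit, compound 3 is expected to sit at the limit too, and the step that the limit leaves unreadable from compound 2 to compound 3 is estimated to stay within the scatter. Compound 3 is estimated at 30000 nM, with a range from 12000 nM to 80000 nM.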

Compound 3, half-maximal effective concentration: > 26000 nM
Compound 3 ended at the assay's limit (the forecaster's own chance of this, stated with the estimate: 80%); the middle value lies beyond the limit too.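

Going by these compounds alone, no step among compound 1, compound 2 and compound 3 can be read in this assay, since all three values are limits of the assay and not numbers: the limit of > 26000 nM in this assay, at which 3 of the 3 values shown sit.

Still open is whether the pyridin-4-yl, 3,5-dimethoxyphenyl and 3-fluoro-5-methoxyphenyl groups differ at all on this read-out, and at what concentration any of these compounds would reach a half-maximal effect.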